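From 4-chlorophenyl to 4-bromophenyl: working notes

The source may report more compounds than this note shows. Statements on the series, on what has been measured and on what is new or still open speak of the compounds shown alone.

Values in a functional assay on HeLa cells (Homo sapiens) for cytotoxicity, read by MTT assay, with a stated time of 24 h; a higher number here means a weaker inhibitor, a lower number a stronger inhibitor:
- compound 1 `CN1C/C(=C\c2ccc(F)cc2)C(=O)/C(=C/c2cccc([N+](=O)[O-])c2)C1`: 6250 nM
- compound 2 `CN1C/C(=C\c2ccc(Cl)cc2)C(=O)/C(=C/c2cccc([N+](=O)[O-])c2)C1`: > 20000 nM

Compound 2 stands at > 20000 nM, which is a limit and not a number. Compound 3 `CN1C/C(=C\c2ccc(Br)cc2)C(=O)/C(=C/c2cccc([N+](=O)[O-])c2)C1` differs from compound 2 by bromo in place of chloro on an aromatic carbon. Among the compounds with values here, the one measured step that bears on this is an at least 3.2-fold higher number from compound 1 to compound 2 (0.50 log units; beyond the scatter), with chloro in place of fluoro on an aromatic carbon, and it ends at a limit. Within the data shown here, with only that step to go on, the expected change in this assay is a number no higher from compound 2 to compound 3 (the limit leaves the size open), nothing beyond the scatter. Compound 3 is estimated at 20000 nM, with an expected range of 8000 nM to 40000 nM.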

Compound 3, half-maximal inhibitory concentration: 11900 nM
Beside the measured number, compound 3's estimate is 1.7-fold (0.23 log units) above it; the measured number falls inside the stated range.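

In this assay, on these data alone, the change from 4-chlorophenyl to 4-bromophenyl at this position gives a lower number (an at least 1.6-fold lower number from compound 2 to compound 3 (0.22 log units; that floor lies within the scatter)), though its true size stays open. Compound 2 carries a limit and not a number: the limit of > 20000 nM in this assay, at which 1 of the 3 values shown sits. Bromo and fluoro at this position cannot be told apart (a 1.9-fold higher number from compound 1 to compound 3 (0.28 log units; within the scatter)), so no steady order runs through the three halogens, and compound 2 is the one that breaks it.

Open, as far as these compounds go, is how an amine or a carboxylic acid in place of the halogen would read. Also open, from the compounds shown here alone, is whether a change elsewhere on the shared core would move the number beyond the scatter.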